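The source may report more compounds than this note shows. Statements on the series, on what has been measured and on what is new or still open speak of the compounds shown alone.

Compound 1, `COc1cc(-c2nnc3n2NC(c2ccco2)C(C(=O)C2CC2)S3)cc(OC)c1OC`, in a functional assay on MCF7 cells (Homo sapiens) for cytotoxicity, read by MTT assay, with a stated time of 48 h (on this read-out lower numbers stand for stronger inhibition and higher numbers for weaker inhibition), gives > 100000 nM, which is a limit of the assay and not a number. Compound 2, `COc1cc(-c2nnc3n2NC(c2ccco2)C(C(=O)c2cccc4ccccc24)S3)cc(OC)c1OC`, in this assay gives > 100000 nM, again a limit. Compound 3, `COc1ccc(C(=O)C2Sc3nnc(-c4cc(OC)c(OC)c(OC)c4)n3NC2c2ccco2)cc1`, in this assay gives > 100000 nM, also a limit.

Compound 3 therefore stands at the top of what this assay reports: it sits at the limit of > 100000 nM in this assay, at which 3 of the 3 values shown sit, together with the other two measured compounds. The three steps among them, a step that the two limits leave unreadable from compound 1 to compound 2, a step that the two limits leave unreadable from compound 1 to compound 3 and a step that the two limits leave unreadable from compound 2 to compound 3, all concern the group on the carbonyl carbon, and none can be read in size, since each joins two limits.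

Compound 4, `COc1cc(-c2nnc3n2NC(c2ccco2)C(C(=O)c2ccc(O)cc2)S3)cc(OC)c1OC`, differs from compound 3 by hydrogen in place of methyl on an oxygen on an aromatic ring. For the measured compounds named here, no measured step touches this oxygen; the measured steps all lie elsewhere in the molecule and carry no readable size, so they give no direction for the change from compound 3 to compound 4. With every measured value at the limit, compound 4 is expected to sit at or near the limit as well, and the expected step of a number no higher from compound 3 to compound 4 (the limit leaves the size open) is one of no readable size. The estimate for compound 4 in this assay is 100000 nM, with a range from 30000 nM to 400000 nM.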

Compound 4, half-maximal inhibitory concentration: 88900 nM
The estimate for compound 4 lay 1.1-fold (0.05 log units) above the measured number, and the stated range covers the measured number.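

For the compounds shown here, with compound 4, this assay gives a number rather than a limit for the first time, and this position on the aromatic ring gives the only step here with a readable floor: replacing methoxy with hydroxy gives an at least 1.1-fold lower number from compound 3 to compound 4 (0.05 log units; that floor lies within the scatter). The 4-hydroxyphenyl group on the carbonyl carbon gives the same floor against the two other groups, with an at least 1.1-fold lower number from compound 2 to compound 4 (0.05 log units; that floor lies within the scatter) and an at least 1.1-fold lower number from compound 1 to compound 4 (0.05 log units; that floor lies within the scatter). Each of these steps starts from a limit, so each gives only a floor that does not by itself establish a real change, and the hydroxy group stands alone among the compounds with a number: the limit of > 100000 nM in this assay, at which 3 of the 4 values shown sit.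

On these data alone, how large the three steps really are stays open, as the true values of compound 1, compound 2 and compound 3 cannot be read from their limits. Also open, as far as these compounds go, is whether an amine or a carboxylic acid in place of the hydroxy on the 4-hydroxyphenyl group would give a number in this range, or whether a hydroxy group on the naphthalen-1-yl group would do the same.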